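This account rests on a few compounds, and the source may have more. Where it says the series, first, only, none or still open, it means among the compounds named here.

Measured so far:
compound 1 `CC(C)(C)Cc1c(-c2cccnc2)sc(N)c1C(=O)c1ccc(Cl)cc1` — 1%
compound 2 `CC(C)(C)Cc1c(-c2cc(F)ccc2F)sc(N)c1C(=O)c1ccc(Cl)cc1` — 1%
compound 3 `Cc1ccccc1-c1sc(N)c(C(=O)c2ccc(Cl)cc2)c1CC(C)(C)C` — 1%

In an assay on CHO cells for displacement of a labelled ligand from adenosine receptor A3 (Homo sapiens), read by scintillation counting, tested at 10 uM (on this read-out lower numbers stand for less inhibition and higher numbers for more inhibition at the one concentration tested (going by the name of the read-out)), compound 3 stands level with compounds 1 and 2: no change at the digits printed from compound 1 to compound 3 (within the scatter) and no change at the digits printed from compound 2 to compound 3 (within the scatter) both show no change within the scatter, and the same holds for no change at the digits printed from compound 1 to compound 2 (within the scatter). Every measured exchange of the aromatic group at this place of the core has therefore left the read-out flat at the bottom of the scale.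

Compound 4 `CC(C)(C)Cc1c(-c2ccco2)sc(N)c1C(=O)c1ccc(Cl)cc1` differs from compound 3 in one place: furan-2-yl in place of 2-methylphenyl on an aromatic carbon. The three measured steps bear directly on this exchange, and each was a step of no size beyond the scatter. No shift beyond the scatter is therefore expected for no change at the digits printed from compound 3 to compound 4 (within the scatter). Compound 4 is expected to give 1%, estimated between -8% and 10%.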

Compound 4, a percentage reported as inhibition, at one concentration (the size of the read-out at that concentration, not a potency): 1%
Estimate against measurement, compound 4: no gap at the digits printed; the range from low to high includes it.
By their numbers in this assay, from the lowest: compounds 1, 2, 3 and 4 (each within the scatter of the next).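

In this assay the place next to the ring sulfur now also takes a five-membered aromatic ring with oxygen as its hetero atom and one hydrogen-bond acceptor, where the earlier groups were all six-membered aromatic rings. The exchange gives no change at the digits printed from compound 3 to compound 4 (within the scatter) and no change at the digits printed from compound 2 to compound 4 (within the scatter) and no change at the digits printed from compound 1 to compound 4 (within the scatter) so neither this ring size nor this hetero atom separates compound 4 from the others. No evidence bears on this flat result.

Open, on these data alone, is whether an amine or a carboxylic acid on the aromatic group at this place would move the read-out. Also open, as far as these compounds go, is whether a shorter chain in place of the neopentyl group would do so.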